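This account rests on a few compounds, and the source may have more. Where it says the series, first, only, none or still open, it means among the compounds named here.

Measured so far:
Compound 1 `Cc1n[nH]c2c1[C@@H](c1ccc(OCc3ccc(Cl)cc3)cc1)S[C@@H](C)C(=O)N2` gives "not determined" (no result reported)
Compound 2 `Cc1n[nH]c2c1[C@@H](c1ccc(OCc3ccccc3F)cc1)S[C@@H](C)C(=O)N2` gives > 200000 nM

Going by the values given here, in an ADME assay on L929 cells (Mus musculus) for cytotoxicity, read by resazurin assay, with a stated time of 96 h (a lower number here means that less compound is tolerated, a higher number that more compound is tolerated), compound 1 has no reported result, which leaves compound 2 as the only guide. Compound 2 stands at the limit of > 200000 nM in this assay, at which 1 of the 2 values shown sits, and that figure is a limit of the assay, not a number.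

Compound 3 `Cc1n[nH]c2c1[C@@H](c1ccc(OCc3cccc(F)c3)cc1)S[C@@H](C)C(=O)N2` keeps the shared core, and its difference from compound 2 is 3-fluorophenyl in place of 2-fluorophenyl on a saturated chain carbon bound to an oxygen on an aromatic ring (2-fluorobenzyl to 3-fluorobenzyl when cut one bond further out). Among the compounds with values here, no measured step is available for this exchange, so no change beyond the usual scatter is expected in this assay in either direction. The expected change is a number no higher from compound 2 to compound 3 (the limit leaves the size open). The outcome for compound 3 is expected to be possibly only a limit again. Compound 3 is estimated at 200000 nM (from 100000 nM to 400000 nM).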

Compound 3, concentration lethal to 50% of the cells: 103000 nM
For compound 3 the middle estimate is 1.9-fold (0.29 log units) above the measured one, and the stated range covers the measured number.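

In this assay, 3-fluorophenyl in place of 2-fluorophenyl on a saturated chain carbon bound to an oxygen on an aromatic ring gives an at least 1.9-fold lower number from compound 2 to compound 3 (0.28 log units; that floor lies within the scatter). The value of compound 2 is a limit of the assay and not a number, so the true size of this step stays open: the limit of > 200000 nM in this assay, at which 1 of the 3 values shown sits. Compound 3 is the only one of the three compounds shown with a single number, so this position now has one firm reading to which later changes can be compared.

The compounds shown leave open how the reading would respond to a methoxy group or an amine on the benzyl ring in place of the fluorine. They also leave open what a longer chain in place of the benzyl group would do.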